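Methyl on the amide nitrogen: a small step, clearance expected low

The source may hold more compounds than are shown below. What is called first, only, known or untested is meant among the compounds shown, and "the series" means these compounds.

Of the compounds shown here, two have been measured in an in vitro ADME assay on microsomes from liver (Homo sapiens) for metabolic stability; on this read-out lower numbers stand for slow clearance and higher numbers for fast clearance. Compound 1, `COc1ccc(-c2cc(-c3ccc(S(=O)(=O)NC4CC4)cc3)cnc2N)cn1`, gives 15 mL.min-1.g-1. Compound 2, `COc1ccc(-c2cc(-c3ccc(C(N)=O)cc3)cnc2N)cn1`, gives < 7 mL.min-1.g-1, which is a limit of the assay and not a number. On the values shown, compound 2 therefore stands at the lowest end, with the limit of < 7 mL.min-1.g-1 in this assay, at which 1 of the 2 values shown sits, marking where it sits.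

The measured step of an at least 2.1-fold lower number from compound 1 to compound 2 (0.33 log units; beyond the scatter) shows that exchanging the cyclopropylsulfamoyl group for carbamoyl lowered clearance in this assay by at least a modest amount.

Compound 3, `CNC(=O)c1ccc(-c2cnc(N)c(-c3ccc(OC)nc3)c2)cc1`, has not yet been tested. It differs from compound 2 in one place: methyl in place of hydrogen on an amide-type nitrogen. Among the measured compounds shown here, no measured step touches this exact change, and the step from compound 1 to compound 2 concerns a different part of the same group, so it bears on it only loosely. Compound 2 starting from a limit leaves little room for a further fall; a small rise within the scatter, or none, is expected. Compound 3 is estimated at 8 mL.min-1.g-1, within 4 mL.min-1.g-1 to 16 mL.min-1.g-1, which means an expected step of an at least 1.1-fold higher number from compound 2 to compound 3 (0.05 log units; that floor lies within the scatter).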

Compound 3, intrinsic clearance in microsomes: < 7 mL.min-1.g-1
Compound 3 gave a limit, no number; the forecaster's own chance of this, stated with the estimate: 40%; middle value at least 1.1-fold (0.05 log units) from the limit.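

Methyl on the amide nitrogen leaves compound 3 at the same limit of the assay as compound 2 in this assay, a limit and not a number: the limit of < 7 mL.min-1.g-1 in this assay, at which 2 of the 3 values shown sit. The step between these two compounds cannot be read, so the methyl may change clearance a little or not at all, but it does not lift compound 3 off that limit. The comparison that can be read is with the cyclopropylsulfamoyl group: methylcarbamoyl in its place gives an at least 2.1-fold lower number from compound 1 to compound 3 (0.33 log units; beyond the scatter), so the fall in clearance first seen with carbamoyl still holds when the amide nitrogen carries a methyl.

As far as these compounds go, how far compound 2 and compound 3 lie under the limit stays unknown, and any real difference between them stays hidden with it. From the compounds shown here alone, it also remains open whether clearance stays this low with something larger on the amide nitrogen, such as an ethyl group or a longer chain, or with a carboxylic acid in place of the amide altogether.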